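Removing the methoxy from the fused ring system

A few compounds are considered here, and "the series" means these few. Any claim that something is new, unique, unknown or untested is made for them only; others in the source may bear on it.

Measured in a functional assay on HT-29 cells (Homo sapiens) for inhibition, read by sulforhodamine B assay, with a stated time of 48 h; on this read-out lower numbers stand for stronger inhibition of growth and higher numbers for weaker inhibition of growth:
compound 1 `COc1ccc(-c2[nH]c3ccccc3c2/C=C(\C#N)S(=O)(=O)c2ccccc2)cc1`: 314 nM
compound 2 `CC(=O)/C(=C\c1c(-c2ccccc2)[nH]c2ccccc12)S(=O)(=O)c1ccccc1`: 589 nM
compound 3 `COc1ccc2[nH]c(-c3ccccc3)c(/C=C(\C#N)S(=O)(=O)c3ccccc3)c2c1`: 3500 nM

Compound 3 gives the highest of the three numbers in this assay; its nearest neighbour on the read-out is compound 2 and its furthest is compound 1, and both of those gaps lie beyond the scatter, so compound 3 is the least potent of the measured set.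

Compound 4 `N#C/C(=C\c1c(-c2ccccc2)[nH]c2ccccc12)S(=O)(=O)c1ccccc1` is not yet measured. It differs from compound 3 in one place: hydrogen in place of methoxy on an aromatic carbon. Going by the values given here, no single-point step between measured compounds is available, so the size of this step cannot be read off directly. What the numbers show is that the two compounds without a methoxy on the fused ring system, compound 1 and compound 2, both sit well below compound 3. Compound 4 is therefore expected to move in the direction of lower numbers, by a step of a 7.0-fold lower number from compound 3 to compound 4 (0.85 log units; beyond the scatter), beyond the scatter. For compound 4 the estimate in this assay is 500 nM, in the range 150 nM to 1700 nM.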

Compound 4, concentration for 50% growth inhibition: 595 nM
Compound 4: middle estimate off by 1.2-fold (0.08 log units), on the low side; the measured number falls inside the stated range.
By their numbers in this assay, from the lowest: compounds 1, 2 and 4 (each within the scatter of the next); then compound 3.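

In this assay the step at this position can now be read directly: hydrogen in place of methoxy on the fused system gives a 5.9-fold lower number from compound 3 to compound 4 (0.77 log units; beyond the scatter) and shows that the methoxy on this aromatic carbon, para to a fused ring, goes with weaker growth inhibition in this pair. The same replacement on a different aromatic carbon gives a 1.9-fold higher number from compound 1 to compound 4 (0.28 log units; within the scatter) and stays within the scatter, so in these two pairs the outcome depends on where the methoxy sits. Going by these compounds alone, with no methoxy on the compound, cyano in place of acetyl gives a 1.0-fold higher number from compound 2 to compound 4 (0.00 log units; within the scatter) and also stays within the scatter, so the two groups are not told apart here.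

Going by these compounds, how a hydroxyl, a fluorine or an amine on this aromatic carbon would compare with hydrogen and methoxy remains open. Nothing available accounts for the dependence on methoxy position.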